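Oxazole-piperazine amides: aryl exchange on the ring nitrogen

A few compounds are considered here, and "the series" means these few. Any claim that something is new, unique, unknown or untested is made for them only; others in the source may bear on it.

Two compounds of the series carry a measurement. Compound 1 `COc1cc(OC)cc(N2CCN(C(=O)c3oc(C)nc3-c3cccc(F)c3)CC2)c1` and compound 2 `Cc1nc(-c2ccccc2)c(C(=O)N2CCN(c3cccc(C(F)(F)F)c3)CC2)o1` were both tested in a functional assay on HL-60 cells (Homo sapiens) for inhibition, read by MTT assay, with a stated time of 72 h; a higher number here means a weaker inhibitor, a lower number a stronger inhibitor; compound 1 gives 28.2 nM, and compound 2 gives 153 nM. Compound 2 therefore stands at the higher of the two numbers, and the gap to compound 1 lies beyond the usual scatter. For the measured compounds named here, the two differ at more than one place, so no single step connects them, and nothing beyond the two values themselves can be read from the pair.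

Compound 3 `C=C(C)c1ccc(N2CCN(C(=O)c3oc(C)nc3-c3ccccc3)CC2)cc1` has not yet been measured. Against compound 2 the change is confined to one site: 4-(1-methylethenyl)phenyl in place of 3-(trifluoromethyl)phenyl on an amine nitrogen in a ring. The remainder of the molecule is unchanged.

Going by the values given here, no step between measured compounds is available that would anchor this exchange. With only the value of compound 2 as reference, the number for compound 3 is expected to stay close to it, with no movement beyond the scatter; the estimated step is a 1.1-fold higher number from compound 2 to compound 3 (0.05 log units; within the scatter). Compound 3 is thus estimated at 170 nM, with a range from 45 nM to 650 nM.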

Compound 3, half-maximal inhibitory concentration: "not active" (no number reported)
Compound 3 has no reported number here, and the estimate cannot be compared.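

In this assay, for the compounds shown here, compound 3 is reported as not active without a number, so no step from compound 2 can be read. No supporting data bear on this result. The compounds shown leave open how far 4-(1-methylethenyl)phenyl in place of 3-(trifluoromethyl)phenyl on the ring nitrogen shifts the number.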